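This account rests on a few compounds, and the source may have more. Where it says the series, first, only, none or still open, it means among the compounds named here.

Measured compounds:
- compound 1, `Cc1cc(O)c(C(=O)/C=C/c2ccc(Cl)cc2)c(-c2ccccc2)c1C(=O)/C=C/c1ccc(Cl)cc1`, 30000 nM in a functional assay on HeLa cells (Homo sapiens) for cytotoxicity, read by MTT assay, with a stated time of 24 h; on this read-out higher numbers stand for weaker inhibition and lower numbers for stronger inhibition
- compound 2, `Cc1cc(O)c(C(=O)/C=C/c2ccc(OCc3ccccc3)cc2)c(-c2ccc(Br)cc2)c1C(=O)/C=C/c1ccc(OCc2ccccc2)cc1`, "not active" (no number reported) in this assay
- compound 3, `Cc1cc(O)c(C(=O)/C=C/c2ccccc2)c(-c2ccc(OCc3ccccc3)cc2)c1C(=O)/C=C/c1ccccc1`, "not active" (no number reported) in this assay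

For the measured compounds named here, compound 1 holds the only number in this assay; compound 2 and compound 3 carry no number, only the statement that no activity was seen. Compound 1 therefore stands as the one weakly measurable entry of this small set.

Compound 4, `Cc1cc(O)c(C(=O)/C=C/c2ccc(Cl)cc2)c(-c2ccc(OCc3ccccc3)cc2)c1C(=O)/C=C/c1ccc(Cl)cc1`, is not yet measured. It differs from compound 1 by benzyloxy in place of hydrogen on an aromatic carbon. Going by the values given here, no step between two measured compounds covers this change, so the size of the step cannot be read from a direct pair. What can be said is that compound 3, which carries the same benzyloxy on the shared core, and compound 2, which carries benzyloxy elsewhere, both gave no measurable activity, while compound 1 without it gave 30000 nM.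

On that basis the step in this assay is expected to run toward weaker inhibition, beyond the scatter, with a real chance that no number is returned: the estimate for compound 4 is 70000 nM, between 25000 nM and 250000 nM. The expected step is a 2.3-fold higher number from compound 1 to compound 4 (0.37 log units; beyond the scatter).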

Compound 4, half-maximal inhibitory concentration: "not active" (no number reported)
Nothing numeric was reported for compound 4; no gap can be computed for the estimate.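

In this assay, for the compounds shown here, compound 4 is reported as not active, so no step from compound 1 can be read. The compounds shown leave open how large the effect of benzyloxy on the shared core is. No measurement shown bears on the cause of this result.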